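Nitrile removal on the pyridyl arm of compound 2

The compounds below may be only part of what the source reports. "The series", "measured", "known", "first", "only" and "open" are said of these compounds alone.

Three compounds of the shared core have thermodynamic solubility numbers. In a physicochemical assay for solubility, read by LC-MS, in phosphate buffer, measured as thermodynamic solubility, with a stated time of 24 h, at pH 7.4 (on this read-out lower numbers stand for lower solubility and higher numbers for higher solubility), compound 1 `Cn1cc(-c2cnc3occ(-c4cccc(C#N)c4)c3c2)cn1` gives 600 nM, compound 2 `Cn1cc(-c2cnc3[nH]cc(-c4ccnc(C#N)c4)c3c2)cn1` gives 2000 nM and compound 3 `COc1cccc(-c2c[nH]c3ncc(-c4cnn(C)c4)cc23)c1` gives 18000 nM. Compound 2 thus stands second highest of the three: its nearest neighbour is compound 1, with a lower number, and its furthest is compound 3, with a higher number; both gaps lie beyond the usual scatter of this assay. Among the measured compounds shown here, no pair of these three differs in only one place, so no single-point step is available as a guide.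

Compound 4 `Cn1cc(-c2cnc3[nH]cc(-c4ccncc4)c3c2)cn1` is the unmeasured partner of compound 2. It differs by hydrogen in place of cyano on an aromatic carbon.

For the measured compounds named here, with no measured single step to rest on, the expected change in this assay from compound 2 to compound 4 is a 1.5-fold higher number from compound 2 to compound 4 (0.18 log units; within the scatter), a small upward move that may not exceed the scatter. For compound 4 the estimate in this assay is 3000 nM, with a plausible range from 1000 nM to 10000 nM.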

Compound 4, solubility: 59000 nM
For compound 4 the middle estimate is 20-fold (1.29 log units) below the measured one; measured number outside the range, above it.
By their numbers in this assay, from the lowest: compound 1; then compound 2; then compound 3; then compound 4.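

In this assay, among the compounds shown here, hydrogen in place of cyano on an aromatic carbon of a six-membered aromatic ring with 1 nitrogen, next to the ring nitrogen, gives a 30-fold higher number from compound 2 to compound 4 (1.47 log units; beyond the scatter) and forms the first single-place step. The earlier compounds shown here differ in more than one place and could not isolate this position. The step now shows that one substituent change here can move the read-out by a large amount, beyond the scatter. Nothing measured here bears on what lies behind the size of this step.

Going by these compounds, it remains open whether an amine, a fluorine atom or a carboxamide on this carbon would give a number closer to compound 2 or to compound 4. The same change on the nitrile-bearing arm of compound 1 also remains to be read.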